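From Propyl to Isopropyl on the Shared Core

This account rests on a few compounds, and the source may have more. Where it says the series, first, only, none or still open, it means among the compounds named here.

Of the compounds shown here, two built on one shared core have so far been measured in a functional assay (brain) for displacement of a labelled ligand, with Rattus norvegicus as the target; a higher number here means a weaker inhibitor, a lower number a stronger inhibitor. Compound 1 `C[C@]1(c2ccccc2)OC[C@H]([C@@H]2CCCCN2)O1` gives 847 nM. Compound 2 `CCC[C@]1(c2ccccc2)OC[C@H]([C@@H]2CCCCN2)O1` gives 69 nM. Among the compounds with values here, the single step measured so far, a 12-fold lower number from compound 1 to compound 2 (1.09 log units; beyond the scatter), came with ethyl in place of hydrogen on a saturated chain carbon bound to a saturated ring carbon, and it was large. Within the data shown here, compound 2 therefore holds the lowest number of the two measured, with compound 1 as its only neighbour at a markedly higher number.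

Compound 3 `CC(C)[C@]1(c2ccccc2)OC[C@H]([C@@H]2CCCCN2)O1` has not yet been measured in this assay. It differs from compound 2 in this way: isopropyl in place of propyl on a saturated ring carbon. The change sits on a saturated ring carbon of a five-membered non-aromatic ring, between two ring oxygen atoms. Among the measured compounds shown here, the one measured step shows that a longer chain lowered the number strongly, but nothing measured separates propyl from isopropyl. The chemist therefore expects for compound 3 only a small step, a 1.4-fold higher number from compound 2 to compound 3 (0.16 log units; within the scatter), in this assay. The estimate for compound 3 is 100 nM, within a range from 30 nM to 350 nM.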

Compound 3, inhibition constant: 45 nM
Compound 3: the middle estimate sits 2.2-fold (0.35 log units) above what was measured; measured number inside the range.
By their numbers in this assay, from the lowest: compounds 3 and 2 (each within the scatter of the next); then compound 1.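

In this assay, the saturated ring carbon between two ring oxygen atoms accepts isopropyl as readily as propyl: the two chains, which hold the same number of carbon atoms, cannot be told apart here (a 1.5-fold lower number from compound 2 to compound 3 (0.19 log units; within the scatter)). The large difference from the methyl compound therefore does not require an unbranched chain, as it also appears with the branched isopropyl group (a 19-fold lower number from compound 1 to compound 3 (1.27 log units; beyond the scatter)). No supporting evidence is available to explain either step.

The compounds shown leave open how far this position accepts further change, for example whether a longer chain such as butyl, a more highly branched group such as tert-butyl, or a ring such as cyclopropyl would keep the number close to those of compound 2 and compound 3. They also do not show what would happen if a hydroxyl group or an amine were placed on the propyl or isopropyl chain, or whether the same order of methyl against the larger chains would hold with any other change to the shared core.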